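The source may report more compounds than this note shows. Statements on the series, on what has been measured and on what is new or still open speak of the compounds shown alone.

Measured so far:
compound 1 `CCCCn1ccc(-c2ccc(Oc3ccc(C)nc3C)cc2)c(C#N)c1=O` gives 138 nM in a functional assay on CHO cells for positive allosteric modulation of metabotropic glutamate receptor 2 (Homo sapiens), read by scintillation counting and GTPgammaS binding, with a stated time of 30 min; on this read-out lower numbers stand for an effect already at smaller amounts and higher numbers for an effect only at larger amounts of compound
compound 2 `Cc1ccc(Oc2ccc(-c3ccn(CC4CC4)c(=O)c3C#N)cc2)c(C)n1` gives 263 nM in this assay
compound 3 `CCCCn1ccc(-c2ccc(Oc3cccnc3C)c(Cl)c2)c(C#N)c1=O` gives 100 nM in this assay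

Compounds 1 and 2 share one core and differ in a single change, (cyclopropyl in place of propyl on a saturated chain carbon bound to an aromatic nitrogen). The resulting step, a 1.9-fold higher number from compound 1 to compound 2 (0.28 log units; within the scatter), is of a size the assay cannot tell from repeat-to-repeat noise. Compound 3 has a different core; the difference between the two cores is not broken down here. Compound 4 `Cc1ncccc1Oc1ccc(-c2ccn(CC3CC3)c(=O)c2C#N)cc1Cl` has not yet been measured. It stands to compound 3 as compound 2 stands to compound 1, carrying the same change at the same place, (cyclopropyl in place of propyl on a saturated chain carbon bound to an aromatic nitrogen). The step is therefore expected to be of similar size, a 1.9-fold higher number from compound 3 to compound 4 (0.28 log units; within the scatter), resting on the earlier pair. Compound 4 is expected to give about 190 nM in this assay, most likely between 90 nM and 400 nM.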

Compound 4, half-maximal effective concentration: 230 nM
Beside the measured number, compound 4's estimate is 1.2-fold (0.08 log units) below it; low and high end bracket the measured number.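

In this assay, cyclopropyl in place of propyl on a saturated chain carbon bound to an aromatic nitrogen gives a step of the same kind as before (a 2.3-fold higher number from compound 3 to compound 4 (0.36 log units; beyond the scatter)). The two steps agree, so on these two cores the change carried over with little alteration in size: the same change on two cores in this assay, a 1.9-fold higher number (0.28 log units; within the scatter) from compound 1 to compound 2 and a 2.3-fold higher number (0.36 log units; beyond the scatter) from compound 3 to compound 4, 1.2-fold (0.08 log units) apart, within the scatter of two such steps. Two pairs show this for these cores only; they cannot show that the change would carry over to any other core, and they do not explain why the numbers move as they do.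

The compounds shown leave open what other groups at this place would give, such as a longer chain like hexyl or a chain ending in an amine. They also leave open whether any such group would bring the number lower than that of the propyl compounds.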